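Vinyl Sulfone to Plain Vinyl on a Fluorinated Ring

The source may hold more compounds than are shown below. What is called first, only, known or untested is meant among the compounds shown, and "the series" means these compounds.

Compound 2 `C=CS(=O)(=O)c1cc(C(F)(F)F)cc(C(F)(F)F)c1` stands only as a limit in an ADME assay for pharmacokinetics, read by LC-MS, in phosphate buffer, with a stated time of 72 h, at pH 7.4, tested at 250 uM; on this read-out lower numbers stand for a shorter-lived compound and higher numbers for a longer-lived compound: compound 2 gives < 0.017 h, a limit of the assay rather than a number. Compound 1 `C=CC(=O)Oc1cc(C(F)(F)F)cc(C(F)(F)F)c1` likewise gives a limit, < 0.017 h. Both recorded values sit at the limit of < 0.017 h in this assay, at which 2 of the 2 values shown sit, so the step that the two limits leave unreadable from compound 1 to compound 2 cannot be read in size or direction. Compound 3 `C=Cc1cc(C(F)(F)F)cc(C(F)(F)F)c1` differs from compound 2 by vinyl in place of vinylsulfonyl on an aromatic carbon. Within the data shown here, no measured step bears on this change, and the two limits set no size for it. Compound 3 is nevertheless expected to give 150 h, with a range from 50 h to 500 h. The step of an at least 8800-fold higher number from compound 2 to compound 3 (3.94 log units; beyond the scatter) is expected to be large and upward.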

Compound 3, half-life: > 50 h
Compound 3 ended at the assay's limit (the forecaster's own chance of this, stated with the estimate: 85%); the middle value does not contradict the limit.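

In this assay, vinyl in place of vinylsulfonyl on the aromatic carbon gives an at least 2900-fold higher number from compound 2 to compound 3 (3.46 log units; beyond the scatter), and vinyl in place of (vinylcarbonyl)oxy at the same place gives an at least 2900-fold higher number from compound 1 to compound 3 (3.46 log units; beyond the scatter). Among these compounds, these are the first readable steps at this position, where the earlier pair could show no change at all. Both rest on limits of the assay, so they fix a direction and a minimum size, not an exact size. The compounds shown leave open how far compound 3 lies past its limit, and the step between compound 1 and compound 2 still cannot be read. They also leave open where an ethyl group or an acrylamide at this position would stand.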